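Swapping a benzylamino group for cyclopentyl on the carbonyl

The source may hold more compounds than are shown below. What is called first, only, known or untested is meant among the compounds shown, and "the series" means these compounds.

Measured so far:
compound 1, `Cc1ccc(C(=O)N[C@@H](C(=O)N2CCC(c3ccc(Cl)cc3)CC2)C(C)C)cc1`: 25 nM
compound 2, `CC(C)[C@@H](NC(=O)NCc1ccccc1)C(=O)N1CCC(c2ccc(Cl)cc2)CC1`: 180 nM

Both compounds were tested in an assay on THP-1 cells for displacement of a labelled ligand from C-C chemokine receptor type 1 (Homo sapiens); on this read-out lower numbers stand for stronger inhibition and higher numbers for weaker inhibition. Among the compounds with values here, compound 2 gives the higher of the two numbers, standing a 7.2-fold higher number from compound 1 to compound 2 (0.86 log units; beyond the scatter) away from compound 1, which gives the lower number; the one structural change on that step is a benzylamino group replacing a 4-methylphenyl group on the carbonyl carbon.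

Compound 3, `CC(C)[C@@H](NC(=O)C1CCCC1)C(=O)N1CCC(c2ccc(Cl)cc2)CC1`, is the next step from compound 2: cyclopentyl in place of benzylamino on a carbonyl carbon. Read one bond further out, benzylcarbamoyl becomes cyclopentylcarbonyl. Within the data shown here, the only measured step that touches this position is the one from compound 1 to compound 2, and it was sizeable. It tells how compound 2 compares with an aromatic group on the carbonyl carbon, but not with a non-aromatic ring there, so the guidance is indirect.

Compound 3 is therefore expected to give a number in this assay that sits a 2.0-fold lower number from compound 2 to compound 3 (0.30 log units; within the scatter) from compound 2, tending back toward the number of compound 1 without a firm reason to reach it. The estimate for compound 3 is 90 nM, with a range from 25 nM to 350 nM.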

Compound 3, half-maximal inhibitory concentration: 70 nM
Compound 3: middle estimate off by 1.3-fold (0.11 log units), on the high side; the range from low to high includes it.
By their numbers in this assay, from the lowest: compound 1; then compound 3; then compound 2.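

In this assay, the change from benzylamino to cyclopentyl on the carbonyl carbon gives a 2.6-fold lower number from compound 2 to compound 3 (0.41 log units; beyond the scatter) and shows that this position can hold a non-aromatic ring and still give a lower number than compound 2. Cyclopentyl does not fully match 4-methylphenyl, with a 2.8-fold higher number from compound 1 to compound 3 (0.45 log units; beyond the scatter) as the step, and an aromatic ring alone does not sort the three groups, since compound 1 and compound 2 both carry one yet fall on either side of compound 3. No measurement here explains why the numbers differ.

Benzylamino differs from cyclopentyl at once in its ring, its size and its nitrogen with a hydrogen-bond donor, so these compounds leave open which of those differences accounts for the step. A benzyl group on the carbonyl carbon would keep the aromatic ring without the nitrogen, a cyclopentylamino group would keep the nitrogen with the non-aromatic ring, and a cyclohexyl group would test whether the size of the non-aromatic ring matters.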